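The source may report more compounds than this note shows. Statements on the series, on what has been measured and on what is new or still open speak of the compounds shown alone.

Compound 1 `N#C/C(=C\c1ccc([N+](=O)[O-])cc1)C(=O)c1c[nH]c2ccccc12`: 42000 nM
Compound 2 `N#C/C(=C\c1c[nH]c2ccccc12)C(=O)c1c[nH]c2ccccc12`: 8300 nM
Compound 3 `COc1ccc(CNC(=O)/C(C#N)=C/c2ccc[nH]2)cc1`: > 50000 nM

Of the compounds shown here, three have so far been tested in a functional assay on SW480 cells (Homo sapiens) for inhibition, read by MTT assay, with a stated time of 72 h; on this read-out lower numbers stand for stronger inhibition of growth and higher numbers for weaker inhibition of growth. Compound 1 gives 42000 nM and compound 2 gives 8300 nM in this assay. For compound 3 this assay reports only > 50000 nM, which is a limit and not a number. That limit is the limit of > 50000 nM in this assay, at which 1 of the 3 values shown sits. Compound 3 thus stands at the weak end of the three values shown, without a number of its own.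

Compound 4 `COc1ccc(CNC(=O)/C(C#N)=C/c2ccc(Cl)cc2)cc1` differs from compound 3 in one place: 4-chlorophenyl in place of 1H-pyrrol-2-yl on a double-bonded chain carbon bound to a double-bonded chain carbon. Within the data shown here, no pair of measured compounds shows this change, so no measured step guides the expectation. With compound 3 sitting at a limit, the expectation is that the step that the limit leaves unreadable from compound 3 to compound 4 is none beyond the scatter, with a fair chance that this assay again reports only a limit. Compound 4 is therefore estimated at 60000 nM, expected to fall between 15000 nM and 200000 nM.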

Compound 4, concentration for 50% growth inhibition: 10000 nM
Compound 4: the middle estimate sits 6.0-fold (0.78 log units) above what was measured; measured number below the stated range.
By their numbers in this assay, from the lowest: compounds 2 and 4 (each within the scatter of the next); then compound 1. At a limit, above all of these: compound 3.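

Among these compounds, compound 4 gives the first measured step at this place. In this assay, 4-chlorophenyl in place of 1H-pyrrol-2-yl on a double-bonded chain carbon bound to a double-bonded chain carbon, with the rest of the molecule unchanged, gives an at least 5.0-fold lower number from compound 3 to compound 4 (0.69 log units; beyond the scatter), so this position can move the number beyond the scatter. The full size of the step cannot be read because compound 3 sits at a limit: the limit of > 50000 nM in this assay, at which 1 of the 4 values shown sits.

The compounds shown leave open whether the chlorine or the six-membered aromatic ring accounts for the step, a question that a plain phenyl group at this place would address. They also leave open how an amine or a carboxylic acid on that ring would read in this assay.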